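The source may report more compounds than this note shows. Statements on the series, on what has been measured and on what is new or still open speak of the compounds shown alone.

In a functional assay on BaF3 cells (Mus musculus) for inhibition, read by MTT assay, with a stated time of 3 days (on this read-out lower numbers stand for stronger inhibition of growth and higher numbers for weaker inhibition of growth), three compounds sharing one core sit at the weak end of the scale. Compound 1 `O=C(Nc1ccc(Cl)cc1)Nc1ccc(Nc2ncnc3c2OCCN3)cc1` reads > 10000 nM, which is a limit of the assay. Compound 2 `O=C(Nc1ccc(Br)cc1)Nc1ccc(Nc2ncnc3c2OCCN3)cc1` gives 10000 nM. Compound 3 `CC(C)(C)c1cc(NC(=O)Nc2ccc(Nc3ncnc4c3OCCN4)cc2)no1` reads > 10000 nM, again only a limit and not a number. Compound 4 `CC(C)(C)c1cc(NC(=O)Nc2ccc(Nc3ncnc4c3OCCN4)c(F)c2)no1` differs from compound 3 by fluoro in place of hydrogen on an aromatic carbon, ortho to a large group and meta to a large group. Going by these compounds, the nearest measured change is a number no higher from compound 1 to compound 2 (the limit leaves the size open), whose size stays open, and a number no lower from compound 2 to compound 3 (the limit leaves the size open) is open as well. Within the data shown here, no measured step adds fluoro in place of hydrogen. The estimated change is a number no higher from compound 3 to compound 4 (the limit leaves the size open), with nothing expected beyond the scatter. Compound 4 is expected at 10000 nM, within an estimated range of 3000 nM to 20000 nM.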

Compound 4, concentration for 50% growth inhibition: 10000 nM
Compound 4: the middle estimate sits on the measured number at the digits printed; measured number inside the range.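

In this assay, fluoro in place of hydrogen on an aromatic carbon, ortho to a large group and meta to a large group, gives a number no higher from compound 3 to compound 4 (the limit leaves the size open), and compound 4 remains at the weak end of the scale. Compound 3 reads > 10000 nM, which is a limit of the assay. The size of this step cannot be read because that value is not a number: the limit of > 10000 nM in this assay, at which 2 of the 4 values shown sit.

The compounds shown leave open whether a methoxy group or an amine at this position would bring compound 4 to a lower number. They also leave open whether fluoro here would matter on a compound that reads well clear of this limit.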